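Oxazole for Methoxymethyl: Expected Clearance of Compound 4

This account rests on a few compounds, and the source may have more. Where it says the series, first, only, none or still open, it means among the compounds named here.

Of the compounds shown here, three have been measured in an ADME assay on microsomes from liver (Homo sapiens) for metabolic stability; a lower number here means slower removal, a higher number faster removal of the compound. Compound 1 `COC(=O)N1CCC(n2ccc(Cc3nc4ccccc4n3CCCCO)n2)CC1` gives 110 mL.min-1.g-1 in this assay, and compound 2 `O=c1n(Cc2nc3c(n2CCCCO)CCCC3)c2cnccc2n1C1CC1` gives 65 mL.min-1.g-1. Compound 3 `COCc1cn(CCCCO)c(Cn2c(=O)n(C3CC3)c3ccncc32)n1` gives 9 mL.min-1.g-1, the lowest of the three numbers; the gap to compound 2, its nearest neighbour, lies beyond the usual scatter, and the gap to compound 1 is wider still.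

Compound 4 `O=c1n(Cc2nc(-c3ncco3)cn2CCCCO)c2cnccc2n1C1CC1` has not yet been measured. It differs from compound 3 in one place: 1,3-oxazol-2-yl in place of methoxymethyl on an aromatic carbon. Among the measured compounds shown here, no measured pair in this set carries a change of this kind, so there is no observed step to lean on, and the direction can only be guessed. The expectation is a small rise in this assay, of a size that may stay within the usual scatter. Compound 4 is therefore expected to give 15 mL.min-1.g-1, with a range from 5 mL.min-1.g-1 to 45 mL.min-1.g-1. The step from compound 3 to compound 4 that this estimate means is a 1.7-fold higher number from compound 3 to compound 4 (0.22 log units; within the scatter).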

Compound 4, intrinsic clearance in microsomes: < 8 mL.min-1.g-1
Compound 4: no number, only a limit; the forecaster's own chance of this, stated with the estimate: 10%; middle value at least 1.8-fold (0.27 log units) away from the limit.
By their numbers in this assay, from the lowest: compound 3; then compounds 2 and 1 (each within the scatter of the next). At a limit, below all of these: compound 4.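

In this assay compound 4 gives < 8 mL.min-1.g-1, which is a limit of the assay and not a number. Placing 1,3-oxazol-2-yl on this aromatic carbon, with its 5 heavy atoms and a ring where methoxymethyl has 3 heavy atoms and no ring, brings no rise in the number: the change reads as an at least 1.1-fold lower number from compound 3 to compound 4 (0.05 log units; that floor lies within the scatter), so this position accepts an aromatic ring without faster removal, although the floor of the step cannot by itself separate the two compounds. Compound 4 is also the only compound here that reaches the edge of what the assay can report: the limit of < 8 mL.min-1.g-1 in this assay, at which 1 of the 4 values shown sits.

From the compounds shown here alone, how far under this limit compound 4 truly lies stays open, and with it the real size of the step. Also open, going by these compounds, is whether an amine, a carboxylic acid or a longer chain on the same aromatic carbon would keep the number this low.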